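This account rests on a few compounds, and the source may have more. Where it says the series, first, only, none or still open, it means among the compounds named here.

Compound 3 `C=CCc1cc(C(C)=O)c(O)cc1OCCCCCC` sits second highest of the three compounds measured in an assay on isolated protein for inhibition of leukotriene B4 receptor 1 (Homo sapiens), tested at 10 uM (on this read-out higher numbers stand for more inhibition at the one concentration tested (going by the name of the read-out) and lower numbers for less inhibition), where compound 3 gives 50%. Above it stands compound 2 `C=CCc1cc(C(C)=O)c(O)cc1OCCCCCC#N`, which in this assay gives 81%. Compound 1 `C=CCc1cc(C(C)=O)c(O)cc1OCC#N` stands lowest of the three, and in this assay compound 1 gives 20%. The step of a number 31 percentage points lower from compound 2 to compound 3 (beyond the scatter) is the one that matters here, since compound 4 `C=CCc1cc(C(C)=O)c(O)cc1OCCCCCC(C)=O` is made from compound 3 by the reverse kind of change at the same place: acetyl in place of methyl on a saturated chain carbon, five bonds along the chain from an oxygen on an aromatic ring. The step of a number 30 percentage points higher from compound 1 to compound 3 (beyond the scatter) and the step of a number 61 percentage points higher from compound 1 to compound 2 (beyond the scatter) show that a longer chain at this oxygen raises the number whatever group ends it, and that the chain ending in a nitrile in compound 2 gives the highest number of all. A group bearing a hydrogen-bond acceptor entering at the chain end is therefore expected to move the number upward, in this assay by a number 20 percentage points higher from compound 3 to compound 4 (beyond the scatter), though an acetyl is not a nitrile and the size is uncertain. Compound 4 is thus estimated at 70%, within a range from 50% to 88%.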

Compound 4, a percentage reported as inhibition, at one concentration (the size of the read-out at that concentration, not a potency): 98%
Compound 4: middle estimate off by 28 percentage points, on the low side, outside the stated range (above it).
By their numbers in this assay, from the lowest: compound 1; then compound 3; then compound 2; then compound 4.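

In this assay the acetyl end gives a number 48 percentage points higher from compound 3 to compound 4 (beyond the scatter) at this position, so a chain end carrying a carbonyl goes well past what the plain hexyl chain reaches. The acetyl end also gives a number 17 percentage points higher from compound 2 to compound 4 (beyond the scatter) and is thus not interchangeable with the nitrile end, while the whole replacement of the short cyano group gives a number 78 percentage points higher from compound 1 to compound 4 (beyond the scatter) and leaves compound 4 highest of the four. Nothing measured here accounts for this result.

The compounds shown leave open whether a carboxylic acid, an amine or an amide at the chain end would match the acetyl, and whether a longer or shorter chain ending in acetyl would hold the number. On these data alone, each figure comes from a single concentration, so how potent compound 4 is remains unknown.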